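This account rests on a few compounds, and the source may have more. Where it says the series, first, only, none or still open, it means among the compounds named here.

Compound 1 `O=C(O)c1cccc(C2CC2c2ccc(OCc3c(-c4c(Cl)cccc4Cl)noc3C3CC3)cc2Cl)c1`: 34 nM
Compound 2 `Cn1nc(C(=O)O)c2ccc([C@H]3C[C@](O)(c4ccc(OCc5c(-c6c(Cl)cccc6Cl)noc5C5CC5)cc4Cl)C3)cc21`: 50 nM
Compound 3 `Cn1nc(C(=O)O)c2ccc(C3CC3c3ccc(OCc4c(-c5c(Cl)cccc5Cl)noc4C4CC4)cc3Cl)cc21`: 14 nM

In an assay on HEK293 cells for agonist activity at Bile acid receptor (Homo sapiens) (a higher number here means that more compound is needed for the effect, a lower number that less compound is needed), compound 1 stands second highest of the three numbers. Its nearest neighbour is compound 2, whose value lies within the scatter of it, so no order can be read between those two. Compound 3 sits furthest away, with a number lower than that of compound 1 by a step beyond the scatter. Compound 4 `O=C(O)c1cccc([C@@H]2C[C@H]2c2ccc(OCc3c(-c4c(Cl)cccc4Cl)noc3C3CC3)cc2Cl)c1` is the same molecule as compound 1 drawn with both stereocentres resolved: the two compounds have the same atoms and bonds; at least one stereo element is drawn with a configuration in one of them and without one in the other: 2 of 2 stereo elements differ; a stereocentre at a saturated ring carbon is drawn without a configuration in compound 1 and R in compound 4; a stereocentre at a saturated ring carbon is drawn without a configuration in compound 1 and R in compound 4. Going by the values given here, no measured pair shows the effect of such resolution here. The step is expected to be small, either none beyond the scatter or a modest move to a lower number, giving a 1.4-fold lower number from compound 1 to compound 4 (0.13 log units; within the scatter) in this assay. For compound 4 the expected value is 25 nM, in the range 8 nM to 100 nM.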

Compound 4, half-maximal effective concentration: 29 nM
Compound 4: middle estimate off by 1.2-fold (0.06 log units), on the low side; measured number inside the range.
By their numbers in this assay, from the lowest: compound 3; then compounds 4, 1 and 2 (each within the scatter of the next).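

In this assay, the move from no drawn configuration to R at both saturated ring carbons is a 1.2-fold lower number from compound 1 to compound 4 (0.07 log units; within the scatter), so this resolution brings no change that can be read. Going by these compounds alone, this is the first pair to differ in one place, and it isolates a single feature: the fact that one of compounds 1 and 4 is drawn with a defined configuration and the other without, at the place where they differ. The compounds shown leave open how the other configurations at these two carbons would read in this assay. They also leave open how a tetrazole in place of the carboxylic acid would read on this resolved compound.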